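The source may report more compounds than this note shows. Statements on the series, on what has been measured and on what is new or still open speak of the compounds shown alone.

Compound 3 `COc1ccc(CNC(=O)c2cc(-c3cncc(C)c3)ncc2-c2cncc(F)c2)nc1OC` gives 10000 nM in an assay on CHO cells for antagonist activity at Orexin/Hypocretin receptor type 1 variant I408V (Homo sapiens), read by FLIPR, with a stated time of 5 min (on this read-out higher numbers stand for weaker inhibition and lower numbers for stronger inhibition), and stands level with compound 1, the two together at the highest number of the three. Compound 1 `COc1ccc(CNC(=O)c2cc(-c3cncc(C)c3)ncc2-c2cnn(C)c2)nc1OC` gives 10000 nM in this assay, so the step of no change at the digits printed from compound 1 to compound 3 (within the scatter) stays within the scatter. Compound 2 `COc1ccc(CNC(=O)c2cc(-c3cncc(C)c3)ccc2-c2ccccc2)nc1OC` differs from compound 3 in the shared core and not at this position; in this assay compound 2 gives 1540 nM, the lowest number here and beyond the scatter from compound 3.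

Compound 4 `COc1ccc(CNC(=O)c2cc(-c3cncc(C)c3)ncc2-c2cnccn2)nc1OC` carries pyrazin-2-yl in place of 5-fluoropyridin-3-yl on an aromatic carbon. For the measured compounds named here, the only step that bears on an exchange at this carbon is no change at the digits printed from compound 1 to compound 3 (within the scatter), which showed no change beyond the scatter, so no step beyond the scatter is expected in this assay either. Compound 4 is therefore estimated at 9000 nM, within 3000 nM to 10000 nM, meaning an expected step of a 1.1-fold lower number from compound 3 to compound 4 (0.05 log units; within the scatter).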

Compound 4, half-maximal inhibitory concentration: 10000 nM
Compound 4: the middle estimate sits 1.1-fold (0.05 log units) below what was measured, within the range that was stated.
By their numbers in this assay, from the lowest: compound 2; then compounds 1, 3 and 4 (each within the scatter of the next).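

In this assay the exchange to pyrazin-2-yl gives no change at the digits printed from compound 3 to compound 4 (within the scatter); against the methylpyrazole it gives no change at the digits printed from compound 1 to compound 4 (within the scatter). Three different aromatic rings at this carbon, 1-methyl-1H-pyrazol-4-yl, 5-fluoropyridin-3-yl and pyrazin-2-yl, now stand within the scatter of one another, so the flat result is no longer tied to a single exchange. No evidence at hand accounts for this flat result.

From the compounds shown here alone, whether an amine, a carboxylic acid or a longer alkyl chain at this carbon would separate from these three stays open. Also open, going by these compounds, is whether exchanges here would matter on the core of compound 2.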